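Ring size grows on the aminopyrimidinone nitrogen of compound 2

The source may report more compounds than this note shows. Statements on the series, on what has been measured and on what is new or still open speak of the compounds shown alone.

Compound 2 `Cc1nc(-c2cnc(NC3CC3)[nH]c2=O)ccc1Oc1ccnc(-c2cnn(C)c2)c1` is the lower of the two numbers measured in a functional assay on NFS-60 cells (Mus musculus) for antiproliferative activity, read by resazurin assay, with a stated time of 72 h (a higher number here means a weaker inhibitor, a lower number a stronger inhibitor), where compound 2 gives 55 nM. Its nearest neighbour is compound 1 `CNc1ncc(-c2ccc(Oc3ccnc(-c4cnn(C)c4)c3)c(C)n2)c(=O)[nH]1`, which in this assay gives 1300 nM; the change a 24-fold lower number from compound 1 to compound 2 (1.37 log units; beyond the scatter) came with cyclopropyl in place of methyl on a nitrogen on an aromatic ring. Compound 3 `Cc1nc(-c2cnc(NC3CCOCC3)[nH]c2=O)ccc1Oc1ccnc(-c2cnn(C)c2)c1` takes the same position one stage further: oxan-4-yl in place of cyclopropyl on a nitrogen on an aromatic ring. Among the measured compounds shown here, only the step from compound 1 to compound 2 bears on this, and it shows that enlarging the group on that nitrogen from methyl to cyclopropyl gave a large gain; whether a larger six-membered ring with one hetero atom continues that trend or reverses it cannot be read from a single step. The expected step of a 1.5-fold higher number from compound 2 to compound 3 (0.16 log units; within the scatter) is therefore small, with the number for compound 3 estimated at 80 nM, in the range 20 nM to 400 nM.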

Compound 3, half-maximal inhibitory concentration: 413 nM
Compound 3: middle estimate off by 5.2-fold (0.71 log units), on the low side, and the stated range ends below it.
By their numbers in this assay, from the lowest: compound 2; then compound 3; then compound 1.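

In this assay the change from cyclopropyl to oxan-4-yl brings a 7.5-fold higher number from compound 2 to compound 3 (0.88 log units; beyond the scatter) and so gives back part of the gain made on going from methyl to cyclopropyl, which shows that a larger group on this nitrogen does not simply mean a lower number. Compared with methyl, oxan-4-yl still brings a 3.1-fold lower number from compound 1 to compound 3 (0.50 log units; beyond the scatter) and so compound 3 sits between the other two, leaving cyclopropyl as the best of the three groups at this position. Nothing at hand explains this reversal.

From the compounds shown here alone, whether the loss follows the larger ring or the oxygen within it remains open, and a cyclohexyl group, a carbon-only ring of the same size, would separate the two. Cyclobutyl and cyclopentyl would show how the number moves across the ring sizes in between.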